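A few compounds are considered here, and "the series" means these few. Any claim that something is new, unique, unknown or untested is made for them only; others in the source may bear on it.

Compound 1 `c1ccc2c(-c3cn4ccnc4c(-c4ccc5ncn(C6CCCCC6)c5c4)n3)cccc2c1` gives 3.61% in a functional assay on NCI-H460 cells (Homo sapiens) for inhibition, read by sulforhodamine B assay, with a stated time of 48 h, tested at 10 uM (on this read-out lower numbers stand for less inhibition and higher numbers for more inhibition at the one concentration tested (going by the name of the read-out)), and stands lowest of the three numbers measured, though both other values lie within the scatter of it. Compound 2 `Clc1ccc(-c2cn3ccnc3c(-c3ccc4ncn(C5CCCCC5)c4c3)n2)cc1` gives 4.14% and compound 3 `COc1ccccc1-c1cn2ccnc2c(-c2ccc3ncn(C4CCCCC4)c3c2)n1` gives 9.62%; the steps of a number 0.5 percentage points higher from compound 1 to compound 2 (within the scatter) and a number 6 percentage points higher from compound 1 to compound 3 (within the scatter) both remain within the scatter. Compound 4 `c1ccc(Cn2cnc3ccc(-c4nc(-c5cccc6ccccc56)cn5ccnc45)cc32)cc1` differs from compound 1 in one place: benzyl in place of cyclohexyl on an aromatic nitrogen. Among the measured compounds shown here, no measured step touches that place; each of them exchanges the aryl group on an aromatic carbon, so they bear on the change only by showing that the numbers have so far stayed level, without any step beyond the scatter. The account therefore expects no step beyond the scatter, a number 1.4 percentage points higher from compound 1 to compound 4 (within the scatter). Compound 4 is estimated at 5%, within a range from -5% to 16%.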

Compound 4, a percentage reported as inhibition, at one concentration (the size of the read-out at that concentration, not a potency): 3.8%
Beside the measured number, compound 4's estimate is 1.2 percentage points above it; measured number inside the range.
By their numbers in this assay, from the lowest: compounds 1, 4, 2 and 3 (each within the scatter of the next).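

In this assay, among the compounds shown here, benzyl in place of cyclohexyl on the aromatic nitrogen, the first step at this place, gives a number 0.2 percentage points higher from compound 1 to compound 4 (within the scatter) and so shows that this position, too, takes the exchange of a non-aromatic ring for an aromatic one with no step beyond the scatter. The numbers thus stay level at this place as well as at the aryl group on the aromatic carbon. Nothing available gives a reason for this level result. The compounds shown leave open whether an amine, a carboxylic acid or a longer chain on this nitrogen would bring a step beyond the scatter.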